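A few compounds are considered here, and "the series" means these few. Any claim that something is new, unique, unknown or untested is made for them only; others in the source may bear on it.

Measured so far:
compound 1 `CCNS(=O)(=O)Cc1noc2ccccc12` — 39 mg/kg
compound 2 `CC(C)NS(=O)(=O)Cc1noc2ccccc12` — 56 mg/kg

Both share one core and differ only at the sulfonamide nitrogen substituent. In a functional assay on the whole organism (strain STD-dd) with Mus musculus as the target, in the maximal electroshock model, with a stated time of 2 h (on this read-out lower numbers stand for an effect already at smaller amounts and higher numbers for an effect only at larger amounts of compound), compound 1 gives 39 mg/kg, and compound 2 gives 56 mg/kg. Among the compounds with values here, the only step on record, a 1.4-fold higher number from compound 1 to compound 2 (0.16 log units; within the scatter), is within the scatter, so on these numbers compound 2 cannot be told apart from compound 1; it simply holds the higher of the two values by a margin the assay does not resolve.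

Compound 3 `CN(C)S(=O)(=O)Cc1noc2ccccc12` is not yet measured. Relative to compound 2 it carries dimethylamino in place of isopropylamino on a sulfonyl sulfur. Within the data shown here, no measured step alters the count of hydrogen-bond donors on the sulfonamide nitrogen, so the single step that exists bears on this change only loosely: it shows that reshaping the amine substituent between compound 1 and compound 2 moved the read-out within the scatter. By analogy no step beyond the scatter is expected in this assay, with no firm direction.

Compound 3 is therefore expected to give about 60 mg/kg in this assay, with a range of 30 mg/kg to 120 mg/kg, which means an expected step of a 1.1-fold higher number from compound 2 to compound 3 (0.03 log units; within the scatter).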

Compound 3, dose for half-maximal effect: 37 mg/kg
Compound 3: middle estimate off by 1.6-fold (0.21 log units), on the high side; measured number inside the range.
By their numbers in this assay, from the lowest: compounds 3, 1 and 2 (each within the scatter of the next).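

In this assay, dimethylamino in place of isopropylamino on a sulfonyl sulfur gives a 1.5-fold lower number from compound 2 to compound 3 (0.18 log units; within the scatter), and dimethylamino in place of ethylamino gives a 1.1-fold lower number from compound 1 to compound 3 (0.02 log units; within the scatter). The earlier step, a 1.4-fold higher number from compound 1 to compound 2 (0.16 log units; within the scatter), covered only a methyl on the chain, whereas the new steps include a change from 1 hydrogen-bond donor in isopropylamino to 0 hydrogen-bond donors in dimethylamino, and that change also stays within the scatter, so at this position the read-out does not separate compound 2 from compound 3, and all three compounds remain within the scatter of one another. No supporting data on the compounds are available to explain these results.

Still open, going by these compounds, is whether an unsubstituted amino group, a piperidine or a longer chain such as n-butylamino on the sulfonyl sulfur would give a step beyond the scatter in this assay. Also open is whether the read-out responds to the group at this position at all, or whether the small amines shown simply span too narrow a range to reveal a difference.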